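Swapping Cyano for Methylsulfonyl on Compound 2

This account rests on a few compounds, and the source may have more. Where it says the series, first, only, none or still open, it means among the compounds named here.

Compound 1 `CCn1cnc2c(-c3ccnc(Oc4ccccc4)c3)cnnc21` and compound 2 `CCn1cnc2c(-c3ccc(F)c(-c4ccc(C#N)cc4OC)c3)cnnc21` have both been tested in an ADME assay on microsomes from liver (Homo sapiens) for metabolic stability; a lower number here means slower removal, a higher number faster removal of the compound. Compound 1 gives 51 mL.min-1.g-1 and compound 2 gives 32 mL.min-1.g-1. These two numbers lie within the usual scatter of repeated measurements, so neither compound can be called the more stable. Compound 3 `CCn1cnc2c(-c3ccc(F)c(-c4ccc(S(C)(=O)=O)cc4OC)c3)cnnc21` matches compound 2 except at one place: methylsulfonyl in place of cyano on an aromatic carbon, meta to a methoxy group and para to a large group (methylsulfonyl in place of cyano on an aromatic carbon). For the measured compounds named here, no measured pair of compounds shows this exchange, so the data give no direct guide to its size. The cautious expectation is a small shift toward a lower number, with no change beyond the scatter. The expected change is a 1.2-fold lower number from compound 2 to compound 3 (0.09 log units; within the scatter). For compound 3 the estimated intrinsic clearance is 26 mL.min-1.g-1, with an expected range of 12 mL.min-1.g-1 to 55 mL.min-1.g-1.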

Compound 3, intrinsic clearance in microsomes: < 8 mL.min-1.g-1
Compound 3: no number, only a limit; the forecaster's own chance of this, stated with the estimate: 3%; middle value at least 3.2-fold (0.51 log units) away from the limit.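

Exchanging cyano for methylsulfonyl on the aromatic carbon, meta to a methoxy group and para to a large group, gives an at least 4.0-fold lower number from compound 2 to compound 3 (0.60 log units; beyond the scatter), the first step shown between compounds that differ in one place. It shows that a change at this single position can clearly move the result in this assay, something compound 1 and compound 2 could not show, as they differ in more than one place and their values lie within the scatter. The reading for compound 3 is a limit and not a number, so the full size of the step stays unknown: the limit of < 8 mL.min-1.g-1 in this assay, at which 1 of the 3 values shown sits.

Only cyano and methylsulfonyl are shown at this position, so it stays open whether a carboxylic acid or a sulfonamide there would give a similar step. Also open, on these data alone, is whether this exchange would have a similar effect on another scaffold, such as that of compound 1, which carries neither group.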